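Configuration change at the low end of the series

The compounds below may be only part of what the source reports. "The series", "measured", "known", "first", "only" and "open" are said of these compounds alone.

compound 1 `CC(C)(C)[Si](C)(C)O[C@@H]1CCCO[C@@H]1CO`: > 100000 nM, a limit of the assay
compound 2 `CC(C)(C)[Si](C)(C)O[C@@H]1CCCO[C@@H]1/C=C\C(=O)OCc1ccccc1`: 29000 nM
compound 3 `COC(=O)/C=C\[C@H]1OCCC[C@H]1O[Si](C)(C)C(C)(C)C`: 7300 nM

In a functional assay on A2780 cells (Homo sapiens) for antiproliferative activity, read by sulforhodamine B assay, with a stated time of 48 h (on this read-out higher numbers stand for weaker inhibition of growth and lower numbers for stronger inhibition of growth), compound 3 has the lowest of the two numbers, and the other value is a limit. Compound 4 `COC(=O)/C=C/[C@H]1OCCC[C@@H]1O[Si](C)(C)C(C)(C)C` is still unmeasured and differs from compound 3 in this way: the two compounds have the same atoms and bonds and differ only in configuration as drawn: 2 of 3 stereo elements differ; a stereocentre at a saturated ring carbon is drawn R in compound 3 and S in compound 4; a double bond is drawn Z in compound 3 and E in compound 4. A stereocentre at a saturated ring carbon is drawn R in compound 3 and S in compound 4, and a double bond is drawn Z in compound 3 and E in compound 4.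

Neither measured step changes configuration. The large step of an at least 13-fold lower number from compound 1 to compound 3 (1.13 log units; beyond the scatter) puts 2-(methoxycarbonyl)ethenyl in place of hydroxymethyl, and the modest step of a 4.0-fold lower number from compound 2 to compound 3 (0.60 log units; beyond the scatter) puts hydrogen in place of phenyl. Both therefore bear on it only indirectly, and they show how far numbers move in this small set. With compound 3 at the low end, a slight lean towards a higher number is expected in this assay, with wide uncertainty. The expected step is a 1.9-fold higher number from compound 3 to compound 4 (0.28 log units; within the scatter). For compound 4 the estimated value is 14000 nM, with an expected range of 3500 nM to 55000 nM.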

Compound 4, concentration for 50% growth inhibition: 28000 nM
Compound 4: the middle estimate sits 2.0-fold (0.30 log units) below what was measured; low and high end bracket the measured number.
By their numbers in this assay, from the lowest: compound 3; then compounds 4 and 2 (each within the scatter of the next). At a limit, above all of these: compound 1.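

In this assay, configuration as drawn is enough to move the number, with a 3.8-fold higher number from compound 3 to compound 4 (0.58 log units; beyond the scatter). This is the only step shown in which atoms and bonds stay the same, so the change can be tied to configuration and to nothing else in the structure: the fact that compounds 3 and 4 differ only in the configuration as drawn. Among the compounds shown here, two stereo elements change together, the stereocentre at a saturated ring carbon and the double bond, and the single step does not divide between them.

What each of these two elements contributes alone remains open, as the compounds shown always pair the R stereocentre with the Z double bond and the S stereocentre with the E double bond. Also open, on these data alone, is whether the same sensitivity to configuration would hold with a carboxylic acid or an amide in place of the methyl ester.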